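The source may hold more compounds than are shown below. What is called first, only, known or untested is meant among the compounds shown, and "the series" means these compounds.

Going by the values given here, in an ADME assay (liver) for metabolic stability, with Liver microsome (Rattus norvegicus) as the target, read by LC-MS, using microsomes and NADPH, with stated times of 5 min and 60 min, tested at 4 uM (a higher number here means that more of the compound is left, a lower number that less of the compound is left), compound 1 `Cc1c(OCCCCOCOc2ccc(C(=O)O)cc2)ccc(C(=O)CC2CCCC2)c1O` gives 31%, the lower of the two numbers so far, while compound 2 `COc1cc(C(=O)O)ccc1OCCCCOc1ccc(C(=O)CC(C)C)c(O)c1C` gives 43%, a gap beyond the scatter. Compound 3 `Cc1c(OCCCCOc2ccc(C(=O)O)c(Cl)c2)ccc(C(=O)CC2CCCC2)c1O` has not been measured yet. It differs from compound 1 in one place: 4-carboxy-3-chlorophenyl in place of (4-carboxyphenoxy)methyl on an oxygen on a saturated carbon. Among the compounds with values here, no measured pair shows the effect of a change in one place alone, so any expectation is loose. The expected change is small and upward, within the scatter, and the estimated step is a number 7 percentage points higher from compound 1 to compound 3 (within the scatter). In this assay, compound 3 is expected at 38%, with an estimated range from 20% to 58%.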

Compound 3, percent of the compound remaining: 67%
Beside the measured number, compound 3's estimate is 29 percentage points below it, and the stated range ends below it.
By their numbers in this assay, from the lowest: compound 1; then compound 2; then compound 3.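

In this assay, going by these compounds alone, the step of a number 36 percentage points higher from compound 1 to compound 3 (beyond the scatter) is the first measured change in one place, and it is large. It shows that what sits on this oxygen on a saturated carbon strongly affects how much compound remains. The swap also changes two things at once: the chlorine enters, and the (4-carboxyphenoxy)methyl group with its extra oxygen leaves.

The compounds shown cannot separate these two changes, or tell whether a fluorine or a methyl group in place of the chlorine would behave alike. No measurement here explains the step.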